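A few compounds are considered here, and "the series" means these few. Any claim that something is new, unique, unknown or untested is made for them only; others in the source may bear on it.

Values measured so far in a physicochemical assay for lipophilicity (on this read-out lower numbers stand for lower lipophilicity and higher numbers for higher lipophilicity), are these:
- compound 1 `CC(C)(c1cc([C@@]23CCOC[C@@H]2C3)nc(-c2cccc(O)c2)n1)S(C)(=O)=O` gives 4.8
- compound 2 `Oc1cccc(-c2nccc([C@@]34CCOC[C@@H]3C4)n2)c1` gives 4
- compound 3 `CNCC(=O)Nc1ccc(-c2nc(C(C)(C)S(C)(=O)=O)cc([C@]34CCOC[C@H]3C4)n2)cc1` gives 4.3

Compound 2, at 4 on this scale, lies within the usual scatter of compound 3 at 4.3 on the same scale. Compound 1 stands at 4.8 on that scale. The gap separating compound 1 from compound 2 lies beyond the scatter.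

The next compound is compound 4 `Oc1cccc(-c2nccc(C34CCOCC3C4)n2)c1` and the change from compound 2 is this: the two compounds have the same atoms and bonds; at least one stereo element is drawn with a configuration in one of them and without one in the other: 2 of 2 stereo elements differ; a stereocentre at a saturated ring carbon is drawn S in compound 2 and without a configuration in compound 4; a stereocentre at a saturated ring carbon is drawn R in compound 2 and without a configuration in compound 4 (nothing leaves and nothing enters).

Going by the values given here, the only measured step, a number 0.80 log units lower from compound 1 to compound 2 (beyond the scatter) in this assay, puts hydrogen in place of 1-methyl-1-(methylsulfonyl)ethyl on an aromatic carbon. That is a change of atoms, so its size does not carry over here. Among the compounds with values here, no measured step covers a change in drawn configuration alone.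

With atoms and bonds the same, no step beyond the scatter is expected in this assay, so the expectation starts from compound 2 at 4 as it stands. The estimate amounts to an expected no change at the digits printed from compound 2 to compound 4 (within the scatter) in this read-out.

For compound 4 the estimated value is 4 with an expected range from 3.7 to 4.3 on this scale.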

Compound 4, partition coefficient: 4.1
For compound 4 the middle estimate is 0.10 log units below the measured one; the range from low to high includes it.
By their numbers in this assay, from the lowest: compounds 2, 4 and 3 (each within the scatter of the next); then compound 1.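

In this assay the step is a number 0.10 log units higher from compound 2 to compound 4 (within the scatter), so these two drawings of one structure are not told apart on this scale. The earlier compounds shown here offered only a change of atoms, with hydrogen in place of 1-methyl-1-(methylsulfonyl)ethyl, whereas this pair keeps all atoms and bonds the same and tests the two stereocentres at saturated ring carbons alone. The whole difference within the pair is therefore one of drawn configuration: the fact that one of compounds 2 and 4 is drawn with a defined configuration and the other without, at the place where they differ

Still open, on these data alone, is how a compound with both stereocentres drawn the opposite way would read in this assay, since compound 4 as drawn does not say which configurations it holds. Also open, as far as these compounds go, is how a carboxylic acid or a nitrile, in place of the hydrogen on that aromatic carbon of compound 2, would read.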